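Series notes: urea-to-amide swap reversed with a bromo analogue

The compounds below may be only part of what the source reports. "The series", "measured", "known", "first", "only" and "open" are said of these compounds alone.

In a functional assay on HCT-116 cells (Homo sapiens) for inhibition, read by MTT assay, with a stated time of 2 days, tested at 100 uM (a lower number here means less inhibition of growth, a higher number more inhibition of growth at the concentration tested), compound 1 `CNC(=O)c1cc(Oc2ccc3nc(NC(=O)Nc4ccc(N5CCN(C)CC5)cc4)sc3c2)ccn1` gives 95% and compound 2 `CNC(=O)c1cc(Oc2ccc3nc(NC(=O)Nc4ccc(Cl)cc4)sc3c2)ccn1` gives 85.2%; the step of a number 9.8 percentage points lower from compound 1 to compound 2 (within the scatter) lies within the scatter. Compound 3 `CNC(=O)c1cc(Oc2ccc3nc(NC(=O)c4cccc(F)n4)sc3c2)ccn1` gives 55.5%, the lowest of the three numbers measured; its nearest neighbour is compound 2, and the step of a number 29.7 percentage points lower from compound 2 to compound 3 (beyond the scatter) is beyond the scatter, as is the gap to compound 1.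

Compound 4 `CNC(=O)c1cc(Oc2ccc3nc(NC(=O)Nc4ccc(Br)cc4)sc3c2)ccn1` is not yet measured. The change from compound 3 is (4-bromophenyl)amino in place of 6-fluoropyridin-2-yl on a carbonyl carbon, which restores the carbamoyl arrangement found in compound 2 and compound 1, with bromine in place of chlorine on the aromatic ring. The step that bears on it directly is a number 29.7 percentage points lower from compound 2 to compound 3 (beyond the scatter), here run in reverse. The step of a number 9.8 percentage points lower from compound 1 to compound 2 (within the scatter) shows that varying the group on that aromatic ring changed this assay little, so the bromo compound is expected to sit near compound 2 rather than compound 3. Compound 4 is therefore expected to show a step up in this assay of about a number 28.5 percentage points higher from compound 3 to compound 4 (beyond the scatter). For compound 4 the estimate is 84%, with a range from 70% to 95%.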

Compound 4, percent growth inhibition at one concentration: 80%
For compound 4 the middle estimate is 4 percentage points above the measured one, and the stated range covers the measured number.
By their numbers in this assay, from the lowest: compound 3; then compounds 4, 2 and 1 (each within the scatter of the next, the first and the last beyond it).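

On the carbonyl carbon, the (4-bromophenyl)amino group reverses most of the loss seen with 6-fluoropyridin-2-yl, giving a number 24.5 percentage points higher from compound 3 to compound 4 (beyond the scatter) in this assay, so the earlier drop is no longer tied to a single pair of compounds. On the aromatic carbon, bromo and chloro are not told apart, at a number 5.2 percentage points lower from compound 2 to compound 4 (within the scatter), yet a number 15 percentage points lower from compound 1 to compound 4 (beyond the scatter) shows that replacing 4-methylpiperazin-1-yl can produce a step beyond the scatter, which the chloro compound alone did not show. No measured evidence accounts for either result.

The change from (6-fluoropyridin-2-yl)carbonyl to (4-bromophenyl)carbamoyl alters the ring, the halogen and the amide hydrogen together, so the compounds shown cannot assign the step to any one of them. On these data alone, it also remains open how a morpholine, a carboxylic acid or a methoxy group on that aromatic carbon would compare in this assay, and whether a 4-bromophenyl group attached directly to the carbonyl carbon would retain the number seen for compound 4 (80%).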